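Fluorine position on the benzyl piperazine arm

The source may report more compounds than this note shows. Statements on the series, on what has been measured and on what is new or still open speak of the compounds shown alone.

Two compounds of the series have numbers in a functional assay on Huh-7 cells (Homo sapiens) for antiproliferative activity, read by sulforhodamine B assay, with a stated time of 72 h; a higher number here means a weaker inhibitor, a lower number a stronger inhibitor. Compound 1 `N#Cc1cccc(COc2ccc(-c3cc(CN4CCN(c5ccc(C(F)(F)F)cc5)CC4)no3)cc2)c1` gives 2200 nM. Compound 2 `N#Cc1cccc(COc2ccc(-c3cc(CN4CCN(Cc5ccc(F)cc5)CC4)no3)cc2)c1` gives 1600 nM. Among the compounds with values here, the one step between them, a 1.4-fold lower number from compound 1 to compound 2 (0.14 log units; within the scatter), stays within the scatter, so compound 2 stands at the lower of the two numbers without being separable from compound 1.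

Compound 3 `N#Cc1cccc(COc2ccc(-c3cc(CN4CCN(Cc5ccccc5F)CC4)no3)cc2)c1` is the next member. Its difference from compound 2 is 2-fluorophenyl in place of 4-fluorophenyl on a saturated chain carbon bound to an amine nitrogen in a ring; the same difference, cut one bond further out, reads 4-fluorobenzyl to 2-fluorobenzyl. Within the data shown here, no measured step touches the placement of the fluorine on this phenyl ring. Among the measured compounds shown here, the only step recorded, from compound 1 to compound 2, swaps the whole aryl group for a benzyl group and still lands within the scatter, which gives no sign that this arm moves the read-out much. The expectation for compound 3 is therefore a step of a 1.1-fold higher number from compound 2 to compound 3 (0.03 log units; within the scatter), that is, nothing beyond the scatter. Compound 3 is estimated at 1700 nM, with a range from 600 nM to 4500 nM.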

Compound 3, half-maximal inhibitory concentration: 2400 nM
For compound 3 the middle estimate is 1.4-fold (0.15 log units) below the measured one; low and high end bracket the measured number.
By their numbers in this assay, from the lowest: compounds 2, 1 and 3 (each within the scatter of the next).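

The fluorine placement on this arm now has its first direct reading: in this assay the change from 4-fluorophenyl to 2-fluorophenyl on a saturated chain carbon bound to an amine nitrogen in a ring gives a 1.5-fold higher number from compound 2 to compound 3 (0.18 log units; within the scatter) and stays within the scatter. At this resolution, the assay therefore does not separate the two fluorine placements, although a single pair cannot speak for fluorine placement elsewhere in the series. Within the data shown here, the second new comparison gives a 1.1-fold higher number from compound 1 to compound 3 (0.04 log units; within the scatter) and is also within the scatter, so compound 1, compound 2 and compound 3 form one group with no separable member. No supporting data bear on this result.

Still open, as far as these compounds go, is whether a carboxylic acid or an amine on this phenyl ring, or a longer chain in place of the benzyl carbon, would take the number beyond the scatter. All three arms shown carry only fluorine on an aromatic ring, and the nitrile-bearing end of the shared core stays the same throughout, so the contribution of that end to the read-out remains untested here.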